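The compounds below may be only part of what the source reports. "The series", "measured", "known", "first", "only" and "open" are said of these compounds alone.

Compound 1 `CCOc1cccc2cc(-c3ccc(OC)cc3OC)c(=O)oc12` gives 16600 nM in an assay on CHO cells for displacement of a labelled ligand from adenosine receptor A3 (Homo sapiens), read by radioligand binding; a lower number here means a stronger inhibitor, a higher number a weaker inhibitor. Compound 2 `CC(=O)Oc1ccc2cc(-c3ccccc3)c(=O)oc2c1OC(C)=O` gives 5170 nM in this assay. Compound 3 `CC(=O)Oc1ccc(-c2cc3ccc(OC(C)=O)c(OC(C)=O)c3oc2=O)cc1` gives 6140 nM in this assay.

Among these three numbers compound 3 stands second highest. Its nearest neighbour is compound 2, and the two lie within the usual scatter of each other, so neither can be set above the other. The number furthest from compound 3 belongs to compound 1, whose 16600 nM is higher by a gap that goes beyond the scatter.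

Compound 4 `CC(=O)Oc1ccc(-c2cc3ccc(OC(C)=O)c(OC(C)=O)c3oc2=O)cc1OC(C)=O` differs from compound 3 in one place: acetoxy in place of hydrogen on an aromatic carbon. Within the data shown here, one measured step bears on this change, since it too adds an acetoxy group in place of a ring hydrogen: a 1.2-fold higher number from compound 2 to compound 3 (0.07 log units; within the scatter). That step stayed within the scatter. On that single precedent, the same kind of change from compound 3 to compound 4 is expected to give no step beyond the scatter, a 1.1-fold higher number from compound 3 to compound 4 (0.02 log units; within the scatter). Among the measured compounds shown here, compound 4 is therefore estimated at 6500 nM in this assay, with a likely range from 3000 nM to 14000 nM, the uncertainty reflecting that only one comparable step is available.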

Compound 4, inhibition constant: 23400 nM
Compound 4: middle estimate off by 3.6-fold (0.56 log units), on the low side; the whole stated range lies below it.
By their numbers in this assay, from the lowest: compounds 2 and 3 (each within the scatter of the next); then compounds 1 and 4 (each within the scatter of the next).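

Placed on an aromatic carbon ortho to an acetoxy group and meta to a large group, the new acetoxy makes a clear difference in this assay: a 3.8-fold higher number from compound 3 to compound 4 (0.58 log units; beyond the scatter), a modest but real weakening. The earlier replacement of a ring hydrogen by acetoxy gave a 1.2-fold higher number from compound 2 to compound 3 (0.07 log units; within the scatter), so the two steps show that the same change does not carry the same outcome at every place on these compounds, and that one step within the scatter cannot stand for all such steps. Nothing measured among these compounds accounts for the difference between the two steps.

With a single step at this position, the compounds shown leave open whether the weakening belongs to acetoxy specifically or would follow any replacement of hydrogen there. A hydroxyl, an amine or a fluorine at the same place would separate those two readings, and a compound with this position filled but the neighbouring acetoxy group replaced by hydrogen would show whether the step depends on that neighbour.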